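A few compounds are considered here, and "the series" means these few. Any claim that something is new, unique, unknown or untested is made for them only; others in the source may bear on it.

Working notes on the series.

Compound 1 `COc1ccc(/C=C/C(=O)c2ccccc2OCC(=O)NCCNc2ccnc3cc(Cl)ccc23)cc1` sits second highest of the three numbers in an ADME assay on Vero cells (Chlorocebus sabaeus) for cytotoxicity, read by MTT assay, with a stated time of 72 h (on this read-out higher numbers stand for lower toxicity in this test and lower numbers for higher toxicity in this test), where compound 1 gives 25000 nM. Its nearest neighbour is compound 2 `COc1ccc(/C=C/C(=O)NCCNc2ccnc3cc(Cl)ccc23)cc1`, which in this assay gives 20600 nM, a difference that lies within the scatter, so no order between compound 1 and compound 2 is claimed. Among the measured compounds shown here, the furthest is compound 3 `CC(=O)c1ccccc1OCC(=O)NCCNc1ccnc2cc(Cl)ccc12`, which gives 106000 nM; the one measured step in the set is a 4.2-fold higher number from compound 1 to compound 3 (0.63 log units; beyond the scatter).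

The compound now in question is compound 4 `COc1cc(/C=C/C(=O)c2ccccc2OCC(=O)NCCNc2ccnc3cc(Cl)ccc23)cc(OC)c1OC`. It differs from compound 1 in one place: 3,4,5-trimethoxyphenyl in place of 4-methoxyphenyl on a double-bonded chain carbon bound to a double-bonded chain carbon. For the measured compounds named here, none of the measured steps touches this position: the only step on record replaces the whole 2-(4-methoxyphenyl)ethenyl on the carbonyl carbon with methyl, whereas here the ethenyl link and the aromatic ring are kept and only the methoxy substitution on that ring changes. The step from compound 1 to compound 3 therefore gives no guide to size or direction, and compound 1 and compound 2 are indistinguishable within the scatter. For compound 4 no step beyond the scatter is expected in this assay, so the estimate is no change at the digits printed from compound 1 to compound 4 (within the scatter).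

The expected value for compound 4 in this assay is 25000 nM, with a range from 10000 nM to 60000 nM.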

Compound 4, half-maximal cytotoxic concentration: 3920 nM
Compound 4: the middle estimate sits 6.4-fold (0.80 log units) above what was measured; the measured number lies below the stated range.
By their numbers in this assay, from the lowest: compound 4; then compounds 2 and 1 (each within the scatter of the next); then compound 3.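

In this assay, this position responds to the substitution on the aromatic ring alone: with the ethenyl link and the ring kept, 3,4,5-trimethoxyphenyl in place of 4-methoxyphenyl gives a 6.4-fold lower number from compound 1 to compound 4 (0.80 log units; beyond the scatter), and this lower number stands for higher toxicity in this test. The earlier step, a 4.2-fold higher number from compound 1 to compound 3 (0.63 log units; beyond the scatter), replaced the whole 2-(4-methoxyphenyl)ethenyl with methyl and ran in the opposite direction, so it could not separate the ring substitution from the loss of the entire group, whereas the new step shows that a change confined to the methoxy pattern is enough to move the number beyond the scatter. Nothing at hand accounts for this shift.

The compounds shown leave open whether the number falls gradually with added methoxy groups or depends on this particular pattern, which a 3,4-dimethoxyphenyl, a plain phenyl or a 4-hydroxyphenyl at the same place would help to settle. They also leave open whether the same exchange would have a similar effect on compound 2, which carries the 4-methoxyphenyl on a shorter amide side and whose number lies within the scatter of that of compound 1.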